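Shortening the chain on a dimethylated core: a limit expected

The source may report more compounds than this note shows. Statements on the series, on what has been measured and on what is new or still open speak of the compounds shown alone.

For the measured compounds named here, compound 2 `CC/C=C\C/C=C\C/C=C\CCCCCCCc1cc(=O)c2c(O)cc(OCOC)cc2o1` is the only compound here with a plain number: in a functional assay on MCF7 cells (Homo sapiens) for antiproliferative activity, read by MTT assay (a higher number here means a weaker inhibitor, a lower number a stronger inhibitor), compound 2 gives 17500 nM. Compound 1 `CCCC/C=C\CCCCCCCCCc1cc(=O)c2c(O)cc(OCOC)cc2o1` carries a group of 8 heavy atoms (8 carbon; no ring) in place of a group of 10 heavy atoms (10 carbon; no ring), on a saturated chain carbon, seven bonds along the chain from an aromatic carbon. For compound 1 this assay reports only a limit, > 67200 nM. The step is an at least 3.8-fold higher number from compound 2 to compound 1 (0.58 log units; beyond the scatter), which rests on (the limit of > 67200 nM in this assay, at which 1 of the 3 values shown sits). Compound 3 `CC/C=C\C/C=C\C/C=C\CCCCCCCc1cc(=O)c2c(O)c(C)c(OCOC)c(C)c2o1` differs from compound 2 in its core; the difference between the two cores is not broken down here. For compound 3 this assay again reports only a limit, > 84100 nM, as the limit of > 84100 nM in this assay, at which 1 of the 3 values shown sits, shows. Compound 4 `CCCC/C=C\CCCCCCCCCc1cc(=O)c2c(O)c(C)c(OCOC)c(C)c2o1` differs from compound 3 by a group of 8 heavy atoms (8 carbon; no ring) in place of a group of 10 heavy atoms (10 carbon; no ring), on a saturated chain carbon, seven bonds along the chain from an aromatic carbon, the same change as from compound 2 to compound 1. Since compound 3 already sits at a limit and the earlier step raised the number, compound 4 is expected to give a limit too, an expected step that the limit leaves unreadable from compound 3 to compound 4. Compound 4 is estimated at 200000 nM, expected between 84100 nM and 600000 nM.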

Compound 4, half-maximal inhibitory concentration: > 67200 nM
Compound 4 gave a limit, no number (the forecaster's own chance of this, stated with the estimate: 90%); the middle value does not contradict the limit.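

In this assay, for the compounds shown here, compound 3 and compound 4 both give only limits, so no step between them can be read. The compounds shown leave open whether the oct-3-en-1-yl chain changes the number on the core of compound 3 at all.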